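The source may hold more compounds than are shown below. What is called first, only, known or untested is meant among the compounds shown, and "the series" means these compounds.

Measured compounds:
- compound 1, `CN(C)CCN1CCN(c2nc(-c3ccccn3)nc3c2CN(Cc2ccccc2)CC3)CC1`: 57%
- compound 2, `CN(C)CCN1CCN(c2nc(-c3ccccn3)nc3c2CN(Cc2ccc(F)cc2)CC3)CC1`: "not active" (no number reported)

In an assay on A549 cells with Cystic fibrosis transmembrane conductance regulator variant F508del (Homo sapiens) as the target, read by fluorescence, with a stated time of 25 min (on this read-out higher numbers stand for larger maximal responses and lower numbers for smaller maximal responses), compound 1 reaches 57%. In this assay compound 2 is reported as "not active" (no number reported), with no number attached, so compound 2 cannot be placed on the scale at all; the two measurements share a core and differ only in the group on the benzyl position, yet one gives a clear response and the other none that could be quantified. Compound 3, `CN(C)CCN1CCN(c2nc(-c3ccccn3)nc3c2CN(Cc2ccsc2)CC3)CC1`, has not yet been tested in this assay. It differs from compound 2 by thiophen-3-yl in place of 4-fluorophenyl on a saturated chain carbon bound to an amine nitrogen in a ring. Going by the values given here, no measured pair shows what this particular exchange does, so any expectation rests on the fact that compound 1 responds while compound 2 does not, and on the smaller, five-membered group that enters in compound 3. A step from compound 2 toward a measurable response is possible but far from assured. Compound 3 is expected to reach about 30% in this assay, with a plausible range from 0% to 60%, and a real chance that it too is reported without a number.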

Compound 3, largest response reached (Emax), in percent of the reference or control that the assay uses: "not active" (no number reported)
The entry for compound 3 holds no number, so the estimate cannot be set against anything.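

Going by these compounds alone, compound 2 and compound 3 are both reported as not active, with no number, in this assay, so no step between them can be read. No available evidence bears on this result. The compounds shown leave open whether any group other than the benzyl of compound 1 can give a measurable response on the shared core.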